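The source may report more compounds than this note shows. Statements on the series, on what has been measured and on what is new or still open speak of the compounds shown alone.

Measured compounds:
- compound 1, `O=C(O)Cc1sc(C(c2ccc(F)cc2)c2ccc(F)cc2)nc1-c1ccco1`, in an in vitro assay on HEK385-7 cells for displacement of a labelled ligand from prostaglandin D2 receptor 2 (Homo sapiens) (on this read-out higher numbers stand for weaker inhibition and lower numbers for stronger inhibition), gives 18 nM
- compound 2, `O=C(O)Cc1sc(C(c2ccc(F)cc2)c2ccc(F)cc2)nc1-c1cc(F)nc(F)c1`, in this assay gives 5.4 nM

For the measured compounds named here, compound 2 holds the lowest of the two numbers seen so far in this assay; its only neighbour is compound 1, and the step between them, a 3.3-fold lower number from compound 1 to compound 2 (0.52 log units; beyond the scatter), is modest but beyond the scatter. Compound 3, `O=C(O)Cc1sc(C(c2ccc(F)cc2)c2ccc(F)cc2)nc1-c1ccnc(Cl)c1`, differs from compound 2 in a single place: 2-chloropyridin-4-yl in place of 2,6-difluoropyridin-4-yl on an aromatic carbon. Going by the values given here, the only measured step that touches this position is the one from compound 1 to compound 2, and it changed a five-membered ring for a six-membered one; the exchange of one pyridine substitution pattern for another has no direct precedent in the two numbers available. The earlier step shows that this position can move the number by a modest amount, so a shift of similar size in either direction cannot be ruled out, but nothing points clearly one way. Compound 3 is therefore expected to give about 7 nM in this assay, with a range from 3 nM to 18 nM. This estimate corresponds to an expected step of a 1.3-fold higher number from compound 2 to compound 3 (0.11 log units; within the scatter), which lies within the usual scatter.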

Compound 3, half-maximal inhibitory concentration: 3.1 nM
For compound 3 the middle estimate is 2.3-fold (0.35 log units) above the measured one; the measured number falls inside the stated range.
By their numbers in this assay, from the lowest: compounds 3 and 2 (each within the scatter of the next); then compound 1.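

In this assay, the exchange of 2,6-difluoropyridin-4-yl for 2-chloropyridin-4-yl gives a 1.7-fold lower number from compound 2 to compound 3 (0.24 log units; within the scatter), so on this read-out the two substituted pyridines cannot be told apart, even though one carries two fluorines and the other a single chlorine. The earlier compounds held only one pyridine, whereas there are now two, and the second gives a 5.8-fold lower number from compound 1 to compound 3 (0.76 log units; beyond the scatter), which sits alongside a 3.3-fold lower number from compound 1 to compound 2 (0.52 log units; beyond the scatter); among these three compounds, both pyridines give lower numbers than the furan-2-yl of compound 1, and none of the three goes against this. The data shown offer nothing that would account for these numbers.

Going by these compounds, what remains open is whether any halogen is needed on the pyridine ring at all, which a plain pyridin-4-yl, or a ring with a single fluorine, would begin to settle, and whether an amine or a methoxy group could stand in place of the chlorine. On these data alone, it is also open whether the ring nitrogen matters, a question that a phenyl ring at this position would address, with the rest of the core left unchanged.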